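The compounds below may be only part of what the source reports. "The series", "measured", "known", "first", "only" and "open" are said of these compounds alone.

Compound 1 `O=C(/C=C1\CCc2cc(F)cc(F)c21)NC1CC1`, compound 2 `O=C(/C=C1\CCc2c(F)ccc(F)c21)NC1CC1` and compound 3 `O=C(/C=C1\CCc2ccc(F)cc21)NC1CC1` all carry cyclopropyl on an amide-type nitrogen. In a functional assay on the whole organism with Mus musculus as the target, in the rotarod test (on this read-out higher numbers stand for an effect only at larger amounts of compound and lower numbers for an effect already at smaller amounts), compound 2 gives 2 mg/kg, the lowest number of the three. Compound 3 gives 62 mg/kg and compound 1 gives 81 mg/kg, both higher than compound 2 by more than the scatter. Compound 4 `NC(=O)/C=C1\CCc2c(F)ccc(F)c21` keeps the core of compound 2 and has hydrogen in place of cyclopropyl on an amide-type nitrogen. Among the compounds with values here, no measured pair shows this change, so only a rough expectation is possible: a moderate rise in the number, with an expected 4.0-fold higher number from compound 2 to compound 4 (0.60 log units; beyond the scatter). The estimate in this assay for compound 4 is 8 mg/kg, with an expected range of 2 mg/kg to 35 mg/kg.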

Compound 4, dose for half-maximal effect: 89 mg/kg
For compound 4 the middle estimate is 11-fold (1.05 log units) below the measured one; measured number above the stated range.
By their numbers in this assay, from the lowest: compound 2; then compounds 3, 1 and 4 (each within the scatter of the next).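

In this assay, hydrogen in place of cyclopropyl on the amide-type nitrogen gives a 45-fold higher number from compound 2 to compound 4 (1.65 log units; beyond the scatter), a large step. Within the data shown here, all the earlier compounds carried cyclopropyl, so only this pair shows that the number is sensitive to what sits on this nitrogen, at least with the core of compound 2. Nothing at hand explains the size of this step.

The compounds shown leave open whether a methyl, an isopropyl or a cyclobutyl on this nitrogen would keep the low number of compound 2. They also leave open whether the same change would matter as much with the core of compound 1 or compound 3.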